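Cyclopropyl on the aromatic nitrogen of compound 3

A few compounds are considered here, and "the series" means these few. Any claim that something is new, unique, unknown or untested is made for them only; others in the source may bear on it.

Measured so far in an ADME assay on HeLa cells (Homo sapiens) for cytotoxicity, read by ATP content, with a stated time of 3 days (on this read-out lower numbers stand for higher toxicity in this test and higher numbers for lower toxicity in this test), for three compounds:
- Compound 1 `O=c1n(Cc2cc3cc(Cl)ccc3n2CCCCO)c2cnccc2n1C1CC1` gives > 50000 nM as a limit
- Compound 2 `COc1ccc(-n2c(=O)n(Cc3cc4cc(Cl)ccc4n3CCCC#N)c3cnccc32)cc1OC` gives > 50000 nM as a limit
- Compound 3 `Cn1ccc(-n2c(=O)n(Cc3cc4cc(Cl)ccc4n3CCCC#N)c3cnccc32)n1` gives > 50000 nM as a limit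

Compound 3 has no number in this assay and stands only at its limit (> 50000 nM). The other two compounds are also known only as limits, so the series offers no graded scale.

The next compound, compound 4 `N#CCCCn1c(Cn2c(=O)n(C3CC3)c3ccncc32)cc2cc(Cl)ccc21`, has cyclopropyl in place of 1-methyl-1H-pyrazol-3-yl on an aromatic nitrogen, a change counted as cyclopropyl in place of 1-methyl-1H-pyrazol-3-yl on an aromatic nitrogen and made at the same place on the shared core.

For the measured compounds named here, the one measured step at this nitrogen is a step that the two limits leave unreadable from compound 2 to compound 3 and it gives no size to carry over. What the data do show is the limit of > 50000 nM in this assay, at which 3 of the 3 values shown sit, and this holds across different groups at this nitrogen. Compound 1 also carries cyclopropyl there and is itself a limit (> 50000 nM).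

No step beyond the scatter is therefore expected, in either direction, and the expected step is a number no higher from compound 3 to compound 4 (the limit leaves the size open) on this reasoning. Compound 4 is estimated at 50000 nM with an expected range of 20000 nM to 100000 nM and will most likely be reported only as a limit.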

Compound 4, half-maximal cytotoxic concentration: > 50000 nM
Compound 4 ended at the assay's limit (the forecaster's own chance of this, stated with the estimate: 85%); the middle value lies on the limit itself.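

In this assay compound 4 gives > 50000 nM, which is a limit and not a number. The steps to compound 4 from compound 1, compound 2 and compound 3 cannot be read: the limit of > 50000 nM in this assay, at which 4 of the 4 values shown sit. The compounds shown leave open what size of effect, if any, a change of group at this nitrogen has in this assay.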